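Benzylcarbamoyl in place of benzyl on the oxygen

This account rests on a few compounds, and the source may have more. Where it says the series, first, only, none or still open, it means among the compounds named here.

Measured compounds:
compound 1 `CN(Cc1cn(CC(O)COC(=O)C2CCCCC2)nn1)CC1CCCCC1` gives 18%
compound 2 `CN(Cc1cn(CC(O)COCc2ccccc2)nn1)CC1CCCCC1` gives 6%

In an assay on nucleic acid for inhibition of Nucleic Acid, read by fluorescence, tested at 100 uM (on this read-out higher numbers stand for more inhibition at the one concentration tested (going by the name of the read-out) and lower numbers for less inhibition), compound 2 stands lowest of the two, with compound 1 nearest. Among the compounds with values here, the one measured step, a number 12 percentage points lower from compound 1 to compound 2 (beyond the scatter), bears on the new compound. Compound 3 `CN(Cc1cn(CC(O)COC(=O)NCc2ccccc2)nn1)CC1CCCCC1` differs from compound 2 by benzylcarbamoyl in place of benzyl on an oxygen on a saturated carbon. A carbonyl returns to this oxygen, as in compound 1, so a modest rise is expected, a number 6 percentage points higher from compound 2 to compound 3 (within the scatter), because of a number 12 percentage points lower from compound 1 to compound 2 (beyond the scatter) seen in the opposite direction. Compound 3 is therefore estimated at 12%, within 2% to 25%.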

Compound 3, a percentage reported as inhibition, at one concentration (the size of the read-out at that concentration, not a potency): 32%
Beside the measured number, compound 3's estimate is 20 percentage points below it; measured number above the stated range.
By their numbers in this assay, from the lowest: compound 2; then compound 1; then compound 3.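

In this assay benzylcarbamoyl in place of benzyl on this oxygen gives a number 26 percentage points higher from compound 2 to compound 3 (beyond the scatter) and benzylamino in place of cyclohexyl on the carbonyl carbon gives a number 14 percentage points higher from compound 1 to compound 3 (beyond the scatter) here. A carbonyl on this oxygen therefore does not fix the number by itself: the group it carries also counts. Nothing available explains the rise.

As far as these compounds go, whether the hydrogen-bond donor that enters with benzylcarbamoyl plays any part stays open. So does how a cyclohexylamino group or a longer chain in place of benzylamino on that carbonyl would read.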